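Phenoxy for Phenyl on a Longer Ether Chain

A few compounds are considered here, and "the series" means these few. Any claim that something is new, unique, unknown or untested is made for them only; others in the source may bear on it.

Three measured compounds share a carbamate-protected pyrrolidine joined through an ether chain to a styryl biaryl: compound 1 `CC(C)(C)OC(=O)N1CCC[C@H]1COCCCCCC/C=C/c1ccc(-c2ccccc2)cc1`, compound 2 `CC(C)(C)OC(=O)N1CCC[C@H]1COCCCCCCCCC/C=C/c1ccc(-c2ccccc2)cc1` and compound 3 `CC(C)(C)OC(=O)N1CCC[C@H]1COCCCCCC/C=C/c1ccc(Oc2ccccc2)cc1`. In a functional assay on PANC-1 cells (Homo sapiens) for inhibition, read by XTT assay, with a stated time of 72 h (a higher number here means a weaker inhibitor, a lower number a stronger inhibitor), compound 1 gives only a limit of the assay, > 100000 nM. That value stands at the limit of > 100000 nM in this assay, at which 1 of the 3 values shown sits. The change from compound 1 to the next compound is phenoxy in place of phenyl on an aromatic carbon; in this assay compound 3 gives 63300 nM, so the change made an at least 1.5-fold lower number from compound 1 to compound 3 (0.19 log units; that floor lies within the scatter). Compound 2 gives 80000 nM in this assay; how its core differs from that of compound 1 is not broken down here, and its value and that of compound 3 lie within the usual scatter of each other, so no order between them is claimed.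

Compound 4 `CC(C)(C)OC(=O)N1CCC[C@H]1COCCCCCCCCC/C=C/c1ccc(Oc2ccccc2)cc1` is not yet measured. It differs from compound 2 by phenoxy in place of phenyl on an aromatic carbon, the same change that separates compound 1 from compound 3. Resting on an at least 1.5-fold lower number from compound 1 to compound 3 (0.19 log units; that floor lies within the scatter), the step of a 1.6-fold lower number from compound 2 to compound 4 (0.20 log units; within the scatter) is expected in this assay. Compound 4 is therefore estimated at 50000 nM, most likely between 25000 nM and 100000 nM.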

Compound 4, half-maximal inhibitory concentration: > 100000 nM
Compound 4: only a limit was reported (the forecaster's own chance of this, stated with the estimate: 15%); at least 2.0-fold (0.30 log units) between middle value and limit.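

In this assay compound 4 gives > 100000 nM, which is a limit of the assay and not a number. The step on this core therefore reads an at least 1.2-fold higher number from compound 2 to compound 4 (0.09 log units; that floor lies within the scatter), and beside the earlier step it neither confirms nor rules out that the change carries over: the same change on two cores in this assay, an at least 1.5-fold lower number (0.19 log units; that floor lies within the scatter) from compound 1 to compound 3 and an at least 1.2-fold higher number (0.09 log units; that floor lies within the scatter) from compound 2 to compound 4; the limit leaves it open whether they differ. The pair gives no sign that phenoxy in place of phenyl acts the same way on both cores, but it does not show that the change fails to transfer either, since both steps rest on limits: the limit of > 100000 nM in this assay, at which 2 of the 4 values shown sit.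

The compounds shown leave open how this change would read on a core where both partners give numbers, so that the step has a size and not only a floor. On these data alone, whether a free amine in place of the carbamate, or a shorter ether chain, would bring the values away from the limit also stays open.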